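Substitution on the anilide ring and tolerated concentration

The source may report more compounds than this note shows. Statements on the series, on what has been measured and on what is new or still open speak of the compounds shown alone.

Compound 2 `O=C(Nc1ccccc1)[C@@H]1CCCN1S(=O)(=O)c1cccc2cccnc12` gives 35600 nM in an ADME assay on HEp-2 cells (Homo sapiens) for cytotoxicity (a lower number here means that less compound is tolerated, a higher number that more compound is tolerated), the highest of the three numbers measured. Compound 1 `Cc1ccc(NC(=O)[C@@H]2CCCN2S(=O)(=O)c2cccc3cccnc23)cc1` gives 31700 nM, and the step of a 1.1-fold higher number from compound 1 to compound 2 (0.05 log units; within the scatter) shows that removing that methyl changed nothing beyond the scatter. Compound 3 `Cc1ccc(C(F)(F)F)cc1NC(=O)[C@@H]1CCCN1S(=O)(=O)c1cccc2cccnc12` gives 4800 nM, a clearly lower number than compound 2. Compound 4 `COc1ccc(C)c(NC(=O)[C@@H]2CCCN2S(=O)(=O)c2cccc3cccnc23)c1` differs from compound 2 by 5-methoxy-2-methylphenyl in place of phenyl on an amide-type nitrogen. Among the measured compounds shown here, the only directly comparable step, from compound 1 to compound 2, was flat, but the two values of compound 2 and compound 3 show that a second ring substituent can bring the number down. The author therefore expects a modest downward step a 1.8-fold lower number from compound 2 to compound 4 (0.25 log units; within the scatter), and estimates compound 4 at 20000 nM, within 6000 nM to 50000 nM.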

Compound 4, half-maximal cytotoxic concentration: 44200 nM
Beside the measured number, compound 4's estimate is 2.2-fold (0.34 log units) below it; measured number inside the range.
By their numbers in this assay, from the lowest: compound 3; then compounds 1, 2 and 4 (each within the scatter of the next).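

In this assay a second ring substituent does not by itself bring the number down: 5-methoxy-2-methylphenyl on the amide-type nitrogen gives a 1.2-fold higher number from compound 2 to compound 4 (0.09 log units; within the scatter) and a 1.4-fold higher number from compound 1 to compound 4 (0.14 log units; within the scatter) as well. Methoxy in place of trifluoromethyl gives a 9.2-fold higher number from compound 3 to compound 4 (0.96 log units; beyond the scatter) so, among these compounds, the low number of compound 3 goes with its trifluoromethyl and not with the presence of a second substituent as such. Nothing measured here explains this difference.

The compounds shown leave open whether trifluoromethyl or methoxy would have the same outcome without the accompanying methyl. They also leave open how an amine or a carboxylic acid on this ring would read.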